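Solubility notes on compound 1 and a 4-chlorophenyl analogue

The source may report more compounds than this note shows. Statements on the series, on what has been measured and on what is new or still open speak of the compounds shown alone.

Measured so far in a physicochemical assay for solubility, at pH 7; a higher number here means a more soluble compound, a lower number a less soluble compound:
compound 1, `CN1CCC(C(=O)N2Cc3c(NC(=O)Nc4cccc(F)c4)n[nH]c3C2(C)C)CC1`, gives > 225000 nM
compound 2, `CC(C)CC(=O)Nc1n[nH]c2c1CN(C(=O)C1CCN(C3CC3)CC1)C2(C)C`, gives > 225000 nM

Compound 1 stands at a limit of this assay, not at a number, and so only the side of the limit is known for it. Compound 2 likewise reports a limit of this assay rather than a number. For the measured compounds named here, both values sit on (the limit of > 225000 nM in this assay, at which 2 of the 2 values shown sit), so no step between measured compounds can be worked out, and no ordering of the two is possible.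

Compound 3, `CN1CCC(C(=O)N2Cc3c(NC(=O)c4ccc(Cl)cc4)n[nH]c3C2(C)C)CC1`, is not yet measured. It differs from compound 1 in one place: 4-chlorophenyl in place of (3-fluorophenyl)amino on a carbonyl carbon.

Going by the values given here, with both known values resting on the limit, no measured step gives a direction for this change. The expected step of an at least 1.1-fold lower number from compound 1 to compound 3 (0.05 log units; that floor lies within the scatter) is none beyond the usual scatter, with the understanding that compound 3 may again return only a limit. Compound 3 is therefore expected near 200000 nM in this assay, estimated within 50000 nM to 225000 nM.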

Compound 3, solubility: > 225000 nM
Compound 3 ended at the assay's limit (the forecaster's own chance of this, stated with the estimate: 65%); middle value at least 1.1-fold (0.05 log units) away from the limit.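

In this assay compound 3 gives > 225000 nM, which is a limit and not a number. Compound 1 and compound 3 both rest on a limit, so no step between them can be read: the limit of > 225000 nM in this assay, at which 3 of the 3 values shown sit.

The compounds shown leave open where their actual values lie and whether 4-chlorophenyl in place of (3-fluorophenyl)amino changes the read-out at all.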